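A few compounds are considered here, and "the series" means these few. Any claim that something is new, unique, unknown or untested is made for them only; others in the source may bear on it.

Measured so far:
compound 1, `CC1(C)CC(CNC(=O)CCC(=O)O)C(C)(C)N1[O]`, > 400000 nM
compound 2, `Cc1c(C)c2c(c(C)c1OC(=O)CCC(=O)NC1CC(C)(C)N([O])C(C)(C)C1)CC[C@@](C)(CCC[C@H](C)CCC[C@H](C)CCCC(C)C)O2`, 53000 nM

In a functional assay on MT4 cells (Homo sapiens) for cytotoxicity, read by MTT assay, with a stated time of 72 h (a lower number here means a stronger inhibitor, a higher number a weaker inhibitor), compound 1 gives only a limit, > 400000 nM, so no number is known for it. Among the compounds with values here, compound 2 gives 53000 nM in this assay, and that is the only actual number among the two values shown; the other sits at the limit of > 400000 nM in this assay, at which 1 of the 2 values shown sits.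

Compound 3, `Cc1c(C)c2c(c(C)c1OC(=O)CCC(=O)NCC1CC(C)(C)N([O])C1(C)C)CC[C@@](C)(CCC[C@H](C)CCC[C@H](C)CCCC(C)C)O2`, has not yet been measured. It differs from compound 2 by a group of 11 heavy atoms (9 carbon, 1 nitrogen, 1 oxygen; one five-membered non-aromatic ring with 1 hetero atom) in place of a group of 11 heavy atoms (9 carbon, 1 nitrogen, 1 oxygen; one six-membered non-aromatic ring with 1 hetero atom), on an amide-type nitrogen. The two share every atom and differ only in how the ring attached to the amide-type nitrogen is joined. Within the data shown here, no step between two measured compounds is available, so the size of this change can only be guessed.

Compound 3 is expected to give about 53000 nM in this assay, with a likely range from 20000 nM to 140000 nM, because compound 2 gives 53000 nM and the change rearranges the same atoms. The estimated step of no change at the digits printed from compound 2 to compound 3 (within the scatter) is not expected to go beyond the usual scatter.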

Compound 3, half-maximal inhibitory concentration: 92000 nM
Estimate against measurement, compound 3: 1.7-fold (0.24 log units) below; the range from low to high includes it.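

Within the data shown here, compound 2 and compound 3 provide the first step at this position: replacing the six-membered non-aromatic ring on the amide-type nitrogen with the five-membered one, using the same atoms, gives a 1.7-fold higher number from compound 2 to compound 3 (0.24 log units; within the scatter) in this assay. This assay therefore cannot tell the two ring forms apart, so for these two compounds, how the ring is joined makes no measurable difference to the reading. Nothing measured here offers a reason for this step.

The compounds shown leave open whether a group of a different makeup on the amide-type nitrogen, such as an open chain carrying an amine or a carboxylic acid, would move the number beyond the scatter. They also leave open whether a longer chain between the amide-type nitrogen and the ring would do so.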